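Ring nitrogen substitution in a benzoxazinone biaryl sulfonamide series

A few compounds are considered here, and "the series" means these few. Any claim that something is new, unique, unknown or untested is made for them only; others in the source may bear on it.

Two members of the series have numbers in a functional assay on MCF7 cells (Homo sapiens) for antiproliferative activity, read by MTT assay, with a stated time of 72 h; a lower number here means a stronger inhibitor, a higher number a weaker inhibitor. Compound 1 `O=C1COc2ccc(-c3cccc(NS(=O)(=O)c4ccc(F)cc4)c3)cc2N1` gives 18300 nM in this assay. Compound 2 `O=C1COc2ccc(-c3cnc(Cl)c(NS(=O)(=O)c4ccc(F)cc4)c3)cc2N1c1ccc(F)cc1` gives 32600 nM in this assay. Among the compounds with values here, the two values sit within the usual scatter of each other, so neither compound can be set apart from the other on this read-out; compound 2 carries two changes at once relative to compound 1, so no single step between them is given.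

The next compound is compound 3 `O=C1COc2ccc(-c3cccc(NS(=O)(=O)c4ccc(F)cc4)c3)cc2N1c1ccc(F)cc1`. It differs from compound 1 by 4-fluorophenyl in place of hydrogen on an amide-type nitrogen in a ring. Within the data shown here, no measured pair isolates this change. Among the measured compounds shown here, the only guide is compound 2, which carries the same group on the same nitrogen together with a second change and gives 32600 nM, close to compound 1. On that basis the step from compound 1 to compound 3 is expected to be small, in no set direction, and not beyond the scatter: a 1.1-fold higher number from compound 1 to compound 3 (0.04 log units; within the scatter) is the expected step. Compound 3 is therefore estimated at 20000 nM in this assay, with a range from 8000 nM to 50000 nM.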

Compound 3, half-maximal inhibitory concentration: > 40000 nM
Compound 3 gave a limit, no number (the forecaster's own chance of this, stated with the estimate: 10%); middle value at least 2.0-fold (0.30 log units) away from the limit.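

Within the data shown here, this is the first pair that isolates the amide-type nitrogen in a ring. With the rest of the core of compound 1 unchanged, 4-fluorophenyl in place of hydrogen gives an at least 2.1-fold higher number from compound 1 to compound 3 (0.33 log units; beyond the scatter) in this assay, so the hydrogen-bearing nitrogen and its 4-fluorophenyl counterpart can now be told apart on this read-out. Compound 3 stands at > 40000 nM, which is a limit of the assay and not a number. The printed step therefore gives only the smallest size the change can have, and its full size cannot be read because the reading for compound 3 stops at the limit: the limit of > 40000 nM in this assay, at which 1 of the 3 values shown sits.

The compounds shown leave open whether the step belongs to the 4-fluorophenyl group in particular or to any replacement of the hydrogen on this nitrogen, since only this one group has been isolated here. A methyl group, a benzyl group or a short chain ending in an amine on the same nitrogen would separate those two readings.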